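Shortening the Amine Chain from Compound 2 to Compound 4

The source may report more compounds than this note shows. Statements on the series, on what has been measured and on what is new or still open speak of the compounds shown alone.

Measured so far:
compound 1 `CN(C)CCCNc1nc(-c2ccc(NC(=O)Nc3ccc(F)cc3)cc2)nc2c(Cl)c(Cl)sc12`: 650 nM
compound 2 `CN(C)CCCNc1nc(-c2ccc(NC(=O)Nc3ccccc3Cl)cc2)nc2ccsc12`: 430 nM
compound 3 `CN(C)CCCNc1nc(-c2ccc(NC(=O)Nc3ccc(Cl)cc3Cl)cc2)nc2c(Cl)c(Cl)sc12`: 980 nM

In a functional assay on NCI-H460 cells (Homo sapiens) for cytotoxicity, read by MTT assay, with a stated time of 72 h (on this read-out higher numbers stand for weaker inhibition and lower numbers for stronger inhibition), compound 2 stands at the low end of the three numbers. Compound 1 in this assay gives 650 nM, a gap within the scatter, whereas compound 3 gives 980 nM, a gap beyond it. Going by the values given here, the only step among measured compounds, a 1.5-fold higher number from compound 1 to compound 3 (0.18 log units; within the scatter), concerns the aryl group on the urea and says nothing about the basic side chain. Compound 4 `CN(C)CCNc1nc(-c2ccc(NC(=O)Nc3ccccc3Cl)cc2)nc2ccsc12` differs from compound 2 by dimethylamino in place of (dimethylamino)methyl on a saturated chain carbon, two bonds along the chain from a nitrogen on an aromatic ring. Among the compounds with values here, no measured step bears on this change, so no shift beyond the scatter is expected: a 1.2-fold higher number from compound 2 to compound 4 (0.07 log units; within the scatter) is the estimated step. Compound 4 is therefore expected to give about 500 nM in this assay, within a range of 200 nM to 1300 nM.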

Compound 4, half-maximal inhibitory concentration: 230 nM
The estimate for compound 4 lay 2.2-fold (0.34 log units) above the measured number; the range from low to high includes it.
By their numbers in this assay, from the lowest: compounds 4, 2, 1 and 3 (each within the scatter of the next, the first and the last beyond it).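

Going by these compounds alone, this is the first reading on the amine side chain: with 2-(dimethylamino)ethyl in place of 3-(dimethylamino)propyl, this assay shows a 1.9-fold lower number from compound 2 to compound 4 (0.27 log units; within the scatter). The shorter chain therefore leaves the number within the scatter, so this change at this position gives no shift that can be told apart from repeat measurements. Nothing available accounts for the result. Still open, from the compounds shown here alone, is how a longer chain, or a morpholine in place of dimethylamino, would read here. Also open, going by these compounds, is whether the same shortening reads alike with other aryl groups on the urea.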